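This account rests on a few compounds, and the source may have more. Where it says the series, first, only, none or still open, it means among the compounds named here.

Measured compounds:
- compound 1 `Cn1c(-c2ccc(F)cc2)nc2c(NC3CCCC3)ncnc21`: > 30000 nM
- compound 2 `Cn1c(-c2ccccc2)nc2c(NC3CCC3)ncnc21`: 3730 nM

Of the compounds shown here, two that share a core have been tested in a functional assay on CHO cells for antagonist activity at adenosine receptor A2b (Homo sapiens), read by 33P incorporation, with a stated time of 20 min; on this read-out higher numbers stand for weaker inhibition and lower numbers for stronger inhibition. Compound 1 reaches only a limit of the assay, > 30000 nM, so no number is known for it. Compound 2 gives 3730 nM in this assay. Within the data shown here, compound 2 differs from compound 1 in more than one place, so the two values say only that compound 2 is measurable where compound 1 is not, and no single change can be read from them. The record carries (the limit of > 30000 nM in this assay, at which 1 of the 2 values shown sits).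

The next compound, compound 3 `Cc1cccc(-c2nc3c(NC4CCCC4)ncnc3n2C)c1`, has not yet been measured in this assay. It changes one place of compound 1: 3-methylphenyl in place of 4-fluorophenyl on an aromatic carbon. Nothing measured here shows what this kind of exchange does, so any expectation rests on the fact that compound 1 sits at the limit. Compound 3 is expected to remain weak, with a step of an at least 1.2-fold lower number from compound 1 to compound 3 (0.07 log units; that floor lies within the scatter) that may well lie within the scatter, though a modest gain cannot be ruled out. The estimate for compound 3 is 25000 nM, ranging from 5000 nM to 100000 nM.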

Compound 3, inhibition constant: 6030 nM
Compound 3: the middle estimate sits 4.1-fold (0.62 log units) above what was measured, within the range that was stated.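

In this assay, putting 3-methylphenyl in place of 4-fluorophenyl on this aromatic carbon gives an at least 4.9-fold lower number from compound 1 to compound 3 (0.69 log units; beyond the scatter), so the group at this carbon clearly matters for the read-out, and a single exchange there is enough to bring a compound into the measurable range. Compound 1 gives > 30000 nM, which is a limit of the assay and not a number. The full size of the step therefore stays unknown, and only its smallest possible size can be stated: the limit of > 30000 nM in this assay, at which 1 of the 3 values shown sits.

This exchange alters two things at once, since the fluorine leaves, a methyl group enters, and the substituent's place on the phenyl ring changes, so the compounds shown cannot say which of these accounts for the step. A 3-fluorophenyl or a 4-methylphenyl group at this carbon would begin to separate them, while a phenyl ring carrying an amine or a carboxylic acid would show how far the result extends beyond these small substituents.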